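A New Aryl Group on Compound 3

A few compounds are considered here, and "the series" means these few. Any claim that something is new, unique, unknown or untested is made for them only; others in the source may bear on it.

Of the compounds shown here, three sharing one core have been tested in a functional assay on MDA-MB-231 cells (Homo sapiens) for antiproliferative activity, read by MTT assay, with a stated time of 48 h; on this read-out higher numbers stand for weaker inhibition and lower numbers for stronger inhibition. Compound 1 `CN1CCN(c2ccc(-c3cc4c(N5CCN(S(=O)(=O)N6CCCCC6)CC5)ncnc4s3)cc2)CC1` gives 8130 nM. Compound 2 `CN1CCN(c2ccc(-c3cc4c(N5CCN(S(=O)(=O)C6CC6)CC5)ncnc4s3)cc2)CC1` gives 11500 nM. Compound 3 `CN1CCN(c2ccc(-c3cc4c(N5CCN(C(=O)Nc6ccc(C#N)cc6)CC5)ncnc4s3)cc2)CC1` gives 3930 nM, the lowest of the three numbers and so the strongest inhibition seen so far.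

Compound 4 `CN1CCN(c2ccc(-c3cc4c(N5CCN(C(=O)Nc6ccc(Cl)c(C(F)(F)F)c6)CC5)ncnc4s3)cc2)CC1` has not yet been measured. It differs from compound 3 in one group: 4-chloro-3-(trifluoromethyl)phenyl in place of 4-cyanophenyl on an amide-type nitrogen. Put simply, 4-chloro-3-(trifluoromethyl)phenyl stands in place of 4-cyanophenyl on an amide-type nitrogen.

Going by the values given here, no measured step changes this group directly, so the evidence is indirect. Putting cyclopropyl in place of piperidin-1-yl on the sulfonyl sulfur gave a 1.4-fold higher number from compound 1 to compound 2 (0.15 log units; within the scatter). Exchanging the whole (piperidin-1-yl)sulfonyl group for (4-cyanophenyl)carbamoyl gave a 2.1-fold lower number from compound 1 to compound 3 (0.32 log units; beyond the scatter), which is modest. The largest step available, a 2.9-fold lower number from compound 2 to compound 3 (0.47 log units; beyond the scatter), is also modest, so a swap of the outer ring alone is expected to produce no step beyond the scatter in this assay, with a slight lean towards a lower number. The estimated change is a 1.4-fold lower number from compound 3 to compound 4 (0.15 log units; within the scatter). For compound 4 the expected value is 2800 nM, with an estimated range from 900 nM to 7500 nM.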

Compound 4, half-maximal inhibitory concentration: 2220 nM
Beside the measured number, compound 4's estimate is 1.3-fold (0.10 log units) above it, within the range that was stated.
By their numbers in this assay, from the lowest: compounds 4 and 3 (each within the scatter of the next); then compounds 1 and 2 (each within the scatter of the next).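

Going by these compounds alone, compounds 1, 2 and 3 differ in the whole group on the ring nitrogen, whereas compound 4 is the first to keep the carbonyl and the amide-type nitrogen and change only the aryl group beyond them. In this assay this change gives a 1.8-fold lower number from compound 3 to compound 4 (0.25 log units; within the scatter) and so compound 3 and compound 4 cannot be told apart, even though 4-chloro-3-(trifluoromethyl)phenyl brings 11 heavy atoms in place of 8, and 0 hydrogen-bond acceptors in place of 1. No measured property among the data shown accounts for this result.

Within the data shown here, with only two aryl groups at this position, the separate contributions of the chlorine and the trifluoromethyl group remain unknown, as does the reading of the same compound with an unsubstituted phenyl ring. Also open, as far as these compounds go, is whether a ring bearing a methoxy group or an amine, or a saturated cyclohexyl ring in place of the aryl ring, would move the number beyond the usual scatter.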